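The source may report more compounds than this note shows. Statements on the series, on what has been measured and on what is new or still open speak of the compounds shown alone.

Measured in a functional assay on NCI-H460 cells (Homo sapiens) for inhibition, read by sulforhodamine B assay, with a stated time of 48 h; on this read-out lower numbers stand for higher toxicity in this test and higher numbers for lower toxicity in this test:

Compound 1, `Nc1cc(N)c2nc(-c3ccccc3)c(Oc3ccc(Cl)c(Cl)c3)nc2c1`, is recorded only as a limit of the assay, < 100000 nM.
Compound 2, `CCOC(=O)[C@H](CCC(=O)O)NC(=O)c1ccc(CNc2nc3cc(N)cc(N)c3nc2-c2ccccc2)cc1`, is likewise recorded only as a limit, < 100000 nM.
Compound 3, `Nc1cc(N)c2nc(-c3ccccc3)c(NCc3ccc(Cl)c(Cl)c3)nc2c1`, is also recorded only as a limit, < 100000 nM.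

Compound 3 therefore stands nowhere in particular among the numbers shown: every value shown is a limit rather than a number, and compound 3 shares the limit of < 100000 nM in this assay, at which 3 of the 3 values shown sit, with the other two. Among the measured compounds shown here, no step between measured compounds can be read from such data, so nothing about the effect of exchanging the group on the chain carbon is known from compounds 1, 2 and 3.

Compound 4, `COc1ccc(CNc2nc3cc(N)cc(N)c3nc2-c2ccccc2)cc1OC`, differs from compound 3 in one place: 3,4-dimethoxyphenyl in place of 3,4-dichlorophenyl on a saturated chain carbon bound to a nitrogen on an aromatic ring. For the measured compounds named here, with no measured step to lean on, the expected step in this assay is a step that the limit leaves unreadable from compound 3 to compound 4, none beyond the scatter in either direction, and the most likely outcome is that the assay again reports only its limit. Compound 4 is accordingly estimated at 30000 nM, within a range from 5000 nM to 100000 nM.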

Compound 4, concentration lethal to 50% of the cells: < 100000 nM
Compound 4: only a limit was reported; the forecaster's own chance of this, stated with the estimate: 70%; the middle value lies beyond the limit too.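

No step from compound 3 to compound 4 can be read in this assay, because both compounds are recorded only as a limit of the assay: the limit of < 100000 nM in this assay, at which 4 of the 4 values shown sit.

The compounds shown leave open whether 3,4-dimethoxyphenyl in place of 3,4-dichlorophenyl changes the read-out at all, and how compound 1, compound 2, compound 3 and compound 4 rank against one another.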